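A few compounds are considered here, and "the series" means these few. Any claim that something is new, unique, unknown or untested is made for them only; others in the source may bear on it.

This set holds three measured compounds and one still to be tested in a functional assay on GC3/C1 cells (Homo sapiens) for cytotoxicity, read by MTT assay, with a stated time of 6 days; a higher number here means a weaker inhibitor, a lower number a stronger inhibitor. Compound 1 `CC(=O)N[C@@H](CSC(=O)NCc1ccc(Cl)cc1)C(=O)O` reaches only the limit of the assay, giving > 200000 nM. Compound 2 `COc1ccccc1NC(=O)SC[C@H](NC(C)=O)C(=O)O`, which also carries a methoxy group, likewise shows only a limit, > 200000 nM. Within the data shown here, compound 3 `CC(=O)N[C@@H](CSC(=O)Nc1ccc(Cl)cc1)C(=O)O` is the one compound with an actual number: in this assay compound 3 gives 8130 nM. So compound 3 stands alone among the values shown, the other two resting at the limit of > 200000 nM in this assay, at which 2 of the 3 values shown sit.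

Compound 4 `COc1ccc(NC(=O)SC[C@H](NC(C)=O)C(=O)O)cc1` is compound 3 altered in one place: methoxy in place of chloro on an aromatic carbon. Among the measured compounds shown here, no measured pair shows this exact change, so its size must be judged from the structures and the values alone. In this assay a shift toward a weaker inhibitor is expected, namely a 4.9-fold higher number from compound 3 to compound 4 (0.69 log units; beyond the scatter). For compound 4 the expected result in this assay is 40000 nM, with a range from 8000 nM to 200000 nM, and a fair chance that only a limit is reported.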

Compound 4, half-maximal inhibitory concentration: > 200000 nM
Compound 4: a limit, no number; the forecaster's own chance of this, stated with the estimate: 35%; middle value at least 5.0-fold (0.69 log units) from the limit.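

Replacing chloro with methoxy on this aromatic carbon, para to a large group, gives an at least 24-fold higher number from compound 3 to compound 4 (1.39 log units; beyond the scatter) in this assay. As far as these compounds go, compound 4 gives > 200000 nM, which is a limit and not a number, so the true size of the step stays open. The only measurable value in the set therefore does not survive this single change, and compound 4 joins the other compounds at the limit: the limit of > 200000 nM in this assay, at which 3 of the 4 values shown sit.

The compounds shown leave open whether a smaller or differently built group at this place, such as fluoro, methyl, an amine or a nitrile, would keep a measurable value. They also cannot say which feature of the change matters, whether the loss of the chlorine or the arrival of the oxygen and its added carbon.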